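A few compounds are considered here, and "the series" means these few. Any claim that something is new, unique, unknown or untested is made for them only; others in the source may bear on it.

Going by the values given here, compound 2 `CN(C[C@H]1Cc2c(cccc2N2C[C@H]3CCN(C)[C@H]3C2)CN1)[C@H]1CCCc2cccnc21` stands highest of the two numbers known in an ADME assay on microsomes from liver (Homo sapiens) for metabolic stability, using NADPH, with a stated time of 10 min; a lower number here means that less of the compound is left, a higher number that more of the compound is left: compound 2 gives 97.6%, whereas compound 1 `CN(C[C@H]1Cc2c(cccc2N2CCC(N)CC2)CN1)[C@H]1CCCc2cccnc21` gives 80.8%, the step being a number 16.8 percentage points higher from compound 1 to compound 2 (beyond the scatter). Compound 3 `CN(C[C@H]1Cc2c(cccc2N2C[C@H]3CNC[C@H]3C2)CN1)[C@H]1CCCc2cccnc21` differs from compound 2 in one place: a group of 8 heavy atoms (6 carbon, 2 nitrogen; 2 five-membered non-aromatic rings with 1 hetero atom each) in place of a group of 9 heavy atoms (7 carbon, 2 nitrogen; 2 five-membered non-aromatic rings with 1 hetero atom each), on an aromatic carbon. Among the compounds with values here, no measured step alters this part of the structure in the same way, and the one known step swapped a different group at that place, so it does not directly bear on the change. With compound 2 already near the top of the read-out, no rise beyond the scatter is expected, while a small fall is possible. Compound 3 is therefore estimated at 90%, with a range from 75% to 100%. The expected step of a number 7.6 percentage points lower from compound 2 to compound 3 (within the scatter) is likely to stay within the scatter.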

Compound 3, percent of the compound remaining: 86.7%
Beside the measured number, compound 3's estimate is 3.3 percentage points above it, within the range that was stated.
By their numbers in this assay, from the lowest: compounds 1 and 3 (each within the scatter of the next); then compound 2.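

At this aromatic carbon, two groups that each hold 2 five-membered non-aromatic rings do not read alike in this assay and the change gives a number 10.9 percentage points lower from compound 2 to compound 3 (beyond the scatter) with 1 hydrogen-bond donor in the group that enters and 0 in the group that leaves. Set against the group with one six-membered non-aromatic ring, the entering group gives a number 5.9 percentage points higher from compound 1 to compound 3 (within the scatter) so the higher number of compound 2 is not shared by every group of this ring type. Nothing at hand explains either step.
The compounds shown leave open whether a methyl on the ring nitrogen of compound 3 would by itself raise the number, and how a piperazine or a morpholine would read at the same aromatic carbon.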